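Replacing an Ethenyl-Linked Ring With a Methoxyphenyl Ring

This account rests on a few compounds, and the source may have more. Where it says the series, first, only, none or still open, it means among the compounds named here.

Of the compounds shown here, three sharing one core have been tested in an assay on isolated protein with Bile acid receptor (Homo sapiens) as the target; a higher number here means that more compound is needed for the effect, a lower number that less compound is needed. Compound 1 `COC(=O)/C=C/c1cccc(N(Cc2ccc(/C=C/c3cc(C(F)(F)F)cc(C(F)(F)F)c3)cc2)C(=O)C(C)C)c1` gives 1950 nM. Compound 2 `COC(=O)/C=C/c1cccc(N(Cc2ccc(/C=C/c3c(F)cccc3F)cc2)C(=O)C(C)C)c1` gives 108 nM. Compound 3 `COC(=O)/C=C/c1cccc(N(Cc2ccc(/C=C/c3ccccc3F)cc2)C(=O)NC(C)C)c1` gives 431 nM. Among these three, compound 2 stands at the lowest number, and its steps to compound 3 and to compound 1 both lie beyond the usual scatter, so compound 2 is the most potent of the three in this assay.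

Compound 4 `COC(=O)/C=C/c1cccc(N(Cc2ccc(-c3cccc(OC)c3)cc2)C(=O)C(C)C)c1` has not yet been measured. It differs from compound 2 in one place: 3-methoxyphenyl in place of 2-(2,6-difluorophenyl)ethenyl on an aromatic carbon. Going by the values given here, no measured pair shows a change of this kind, so there is no earlier step to lean on, and the expectation rests on the three numbers alone. The expected step from compound 2 to compound 4 is a moderate rise in the number, a 4.6-fold higher number from compound 2 to compound 4 (0.67 log units; beyond the scatter), with wide uncertainty. Compound 4 is therefore estimated at 500 nM, with a range from 150 nM to 2500 nM.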

Compound 4, half-maximal effective concentration: 72 nM
Compound 4: middle estimate off by 6.9-fold (0.84 log units), on the high side, and the stated range ends above it.
By their numbers in this assay, from the lowest: compounds 4 and 2 (each within the scatter of the next); then compound 3; then compound 1.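

In this assay, exchanging the group on this aromatic carbon, para to a large group, gives a 1.5-fold lower number from compound 2 to compound 4 (0.18 log units; within the scatter), so the two compounds cannot be told apart here. In this pair, the position takes 3-methoxyphenyl as well as 2-(2,6-difluorophenyl)ethenyl, although the entering group has fewer heavy atoms, no fluorine, no double bond outside its aromatic ring, and one hydrogen-bond acceptor. No measurement at hand accounts for this match.

The compounds shown leave open how much the methoxy group itself contributes, which a plain phenyl or a 3-hydroxyphenyl at this position could help to show. They also leave open whether the match between these two groups would hold with a carboxylic acid in place of the methyl ester.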